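Cytotoxicity notes on a methyl-for-hydrogen step

The compounds below may be only part of what the source reports. "The series", "measured", "known", "first", "only" and "open" are said of these compounds alone.

Measured so far:
compound 1 `COc1ncnc(Nc2ccc(Cl)c(OCC=C(C)C)c2)n1`: in an ADME assay on MT2 cells (Homo sapiens) for cytotoxicity (on this read-out higher numbers stand for lower toxicity in this test and lower numbers for higher toxicity in this test), compound 1 gives 18000 nM
compound 2 `CC(C)=CCOc1cc(Nc2ncnc(N)n2)ccc1Cl`: compound 2 gives 48000 nM
compound 3 `CNc1ncnc(Nc2ccc(Cl)c(OCC=C(C)C)c2)n1`: compound 3 gives 3100 nM

Compound 1 holds the second highest of these three numbers: a 2.7-fold higher number from compound 1 to compound 2 (0.43 log units; beyond the scatter), and a 5.8-fold lower number from compound 1 to compound 3 (0.76 log units; beyond the scatter).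

Compound 4 `COc1nc(C)nc(Nc2ccc(Cl)c(OCC=C(C)C)c2)n1` differs from compound 1 in one place: methyl in place of hydrogen on an aromatic carbon. Among the measured compounds shown here, no measured step alters an aromatic carbon in this way. For the measured compounds named here, the only methyl-for-hydrogen step seen, a 15-fold lower number from compound 2 to compound 3 (1.19 log units; beyond the scatter), sits on a ring nitrogen, a different place, so it gives no direct guide. Going by the values given here, with no precedent at this position, a change not beyond the scatter is expected for compound 4, leaning slightly lower. The estimated value for compound 4 is 14000 nM, range 5000 nM to 40000 nM. For compound 4 this means an expected step of a 1.3-fold lower number from compound 1 to compound 4 (0.11 log units; within the scatter).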

Compound 4, half-maximal cytotoxic concentration: 12000 nM
Compound 4: the middle estimate sits 1.2-fold (0.07 log units) above what was measured; the measured number falls inside the stated range.
By their numbers in this assay, from the lowest: compound 3; then compounds 4 and 1 (each within the scatter of the next); then compound 2.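

In this assay, methyl in place of hydrogen on the aromatic carbon between two ring nitrogen atoms gives a 1.5-fold lower number from compound 1 to compound 4 (0.18 log units; within the scatter) and so leaves this read-out within the scatter at this position. The large step seen for methyl on a nitrogen, a 15-fold lower number from compound 2 to compound 3 (1.19 log units; beyond the scatter), does not recur at this carbon. No available evidence bears on this result.

On these data alone, whether ethyl or a carboxylic acid at this carbon would also stay within the scatter of compound 1 remains open. Also open, as far as these compounds go, is whether this methyl gives a similar reading with amino or methylamino in place of methoxy.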